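Chloro to trifluoromethyl at the short-lived end

The source may hold more compounds than are shown below. What is called first, only, known or untested is meant among the compounds shown, and "the series" means these compounds.

In an ADME assay on microsomes from liver (Rattus norvegicus) for metabolic stability, read by LC-MS, using NADPH, at 37 degrees C (on this read-out higher numbers stand for a longer-lived compound and lower numbers for a shorter-lived compound), compound 2 `Cc1oc(-c2c(Cl)cccc2Cl)nc1CN1CCC(C(=O)NCCCN2C[C@H](C)C[C@H](C)C2)CC1` gives 0.0483 h, the lower of the two numbers in the series. Among the compounds with values here, the only other number comes from compound 1 `Cc1ccc(C)c(-c2nc(CN3CCC(C(=O)NCCCN4C[C@H](C)C[C@H](C)C4)CC3)c(C)o2)c1` at 0.5 h. Compound 3 `CCCN(CCC)CCNC(=O)C1CCN(Cc2nc(-c3ccccc3C)oc2C)CC1` reads > 0.5 h, which is a limit of the assay and not a number.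

Compound 4 `Cc1oc(-c2c(Cl)cccc2C(F)(F)F)nc1CN1CCC(C(=O)NCCCN2C[C@H](C)C[C@H](C)C2)CC1` carries trifluoromethyl in place of chloro on an aromatic carbon. Within the data shown here, one measured step bears on this, a 10-fold lower number from compound 1 to compound 2 (1.02 log units; beyond the scatter), a large change, but it exchanges different groups and gives no direction here. The expected step is a 1.4-fold higher number from compound 2 to compound 4 (0.16 log units; within the scatter), with none beyond the scatter anticipated in this assay. For compound 4 the estimate is 0.07 h, with an expected range of 0.025 h to 0.25 h.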

Compound 4, half-life: 0.03 h
For compound 4 the middle estimate is 2.3-fold (0.37 log units) above the measured one; measured number inside the range.
By their numbers in this assay, from the lowest: compounds 4 and 2 (each within the scatter of the next); then compound 1.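

In this assay, within the data shown here, trifluoromethyl in place of chloro on this aromatic carbon gives no step that can be told from the scatter: a 1.6-fold lower number from compound 2 to compound 4 (0.21 log units; within the scatter). The large gap to the 2,5-dimethylphenyl group is therefore not specific to the 2,6-dichlorophenyl group, and it recurs with the 2-chloro-6-(trifluoromethyl)phenyl group: a 17-fold lower number from compound 1 to compound 4 (1.22 log units; beyond the scatter). Nothing at hand gives a cause for either step.

Open, on these data alone, is whether a methyl, a methoxy group or a nitrile on this carbon, with the chloro group kept, would read apart from compound 2 and compound 4.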